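A Fluoro-to-Hydrogen Change Repeated on a Second Core

A few compounds are considered here, and "the series" means these few. Any claim that something is new, unique, unknown or untested is made for them only; others in the source may bear on it.

Of the compounds shown here, three have so far been measured in a functional assay on DU-145 cells (Homo sapiens) for cytotoxicity, read by MTT assay, with a stated time of 2 days, tested at 10 uM; on this read-out higher numbers stand for more inhibition at the one concentration tested (going by the name of the read-out) and lower numbers for less inhibition. Compound 1 `CCCCNc1nc(NCc2ccco2)c2ccccc2n1` gives 89.9%. Compound 3 `CCCCNc1nc(NCc2ccco2)c2cc(F)ccc2n1`, which carries a fluoro on its core, gives 75.4%. Compound 2 `Fc1ccc2nc(NCCCCN3CCN(c4cccc(Cl)c4Cl)CC3)nc(NCc3ccco3)c2c1` gives 95.5%; this is the highest of the three numbers, though its gap to compound 1 lies within the scatter, while its gap to compound 3 lies beyond it.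

The change from compound 3 to compound 1 is hydrogen in place of fluoro on an aromatic carbon, and it brought a number 14.5 percentage points higher from compound 3 to compound 1 (beyond the scatter). Compound 4 `Clc1cccc(N2CCN(CCCCNc3nc(NCc4ccco4)c4ccccc4n3)CC2)c1Cl` is not yet measured; it differs from compound 2 by hydrogen in place of fluoro on an aromatic carbon, the same change at the same place. The difference between the cores of compound 2 and compound 3 is not broken down here.

Compound 2 already gives 95.5%, so little room remains for a rise of the earlier size. The step expected from compound 2 to compound 4 in this assay is a number 1.5 percentage points higher from compound 2 to compound 4 (within the scatter), smaller than the earlier step. The read-out is already close to its top. Compound 4 is estimated at 97%, expected to fall between 89% and 100%.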

Compound 4, a percentage reported as inhibition, at one concentration (the size of the read-out at that concentration, not a potency): 94.3%
Compound 4: middle estimate off by 2.7 percentage points, on the high side; the measured number falls inside the stated range.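

In this assay, hydrogen in place of fluoro on an aromatic carbon of the core of compound 2 gave a number 1.2 percentage points lower from compound 2 to compound 4 (within the scatter), so this step stays within the scatter. The change therefore did not carry the same result from one core to the other: the same change on two cores in this assay, a number 14.5 percentage points higher (beyond the scatter) from compound 3 to compound 1 and a number 1.2 percentage points lower (within the scatter) from compound 2 to compound 4, 15.7 percentage points apart, beyond the scatter of two such steps. Among these compounds, this shows that, in this small series, the step seen on the core of compound 3 cannot be taken over unchanged to the core of compound 2, but it rests on only two pairs, and it does not show why the steps differ or that the fluoro would make no difference on the core of compound 2 under other conditions.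

The compounds shown leave open how a chloro or a methoxy group on that same aromatic carbon would read. They also leave open whether compound 2 and compound 4 would stay within the scatter of each other at a lower concentration, where the read-out would sit further from its top.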